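This account rests on a few compounds, and the source may have more. Where it says the series, first, only, none or still open, it means among the compounds named here.

Measured compounds:
compound 1, `CCCCc1cn(C(c2ccccc2)c2cc3cc(Br)ccc3nc2OC)nn1`, gives 11.1% in an ADME assay on SK-OV-3 cells (Homo sapiens) for cytotoxicity, read by sulforhodamine B assay, with a stated time of 48 h, tested at 10 uM; on this read-out higher numbers stand for more inhibition at the one concentration tested (going by the name of the read-out) and lower numbers for less inhibition;
compound 2, `CCCCCc1cn(C(c2ccccc2)c2cc3cc(Br)ccc3nc2OC)nn1`, gives 10.5%;
compound 3, `CCCc1cn(C(c2ccccc2)c2cc3cc(Br)ccc3nc2OC)nn1`, gives 11.2%.

Compound 3 stands with the highest of the three numbers, but that means little: its nearest neighbour is compound 1, with a number 0.1 percentage points higher from compound 1 to compound 3 (within the scatter), and its furthest is compound 2, with a number 0.7 percentage points higher from compound 2 to compound 3 (within the scatter). The remaining step, a number 0.6 percentage points lower from compound 1 to compound 2 (within the scatter), is also within the scatter. The three compounds share one core and differ only in the length of a single saturated chain, and neither lengthening nor shortening that chain moves the read-out in this assay.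

Compound 4, `COc1nc2ccc(Br)cc2cc1C(c1ccccc1)n1cc(-c2ccccc2C(F)(F)F)nn1`, has not yet been measured. It differs from compound 3 by 2-(trifluoromethyl)phenyl in place of propyl on an aromatic carbon. For the measured compounds named here, none of the measured steps bears directly on this change: each swaps one short chain for another, whereas the new group is an aromatic ring carrying trifluoromethyl, well outside what the three chains cover. The measured steps therefore give no direction, only a baseline of three compounds sitting at about the same low level of inhibition. Compound 4 is expected to remain near that level, with a wide range to allow for the size of the change. The expected step is a number 2.8 percentage points higher from compound 3 to compound 4 (within the scatter). For compound 4 the estimate is 14%, with a range from 2% to 35%.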

Compound 4, a percentage reported as inhibition, at one concentration (the size of the read-out at that concentration, not a potency): 9.55%
Beside the measured number, compound 4's estimate is 4.5 percentage points above it; the measured number falls inside the stated range.
By their numbers in this assay, from the lowest: compounds 4, 2, 1 and 3 (each within the scatter of the next).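

On the aromatic carbon of the five-membered aromatic ring with 3 nitrogen, replacing a saturated chain with 2-(trifluoromethyl)phenyl, a group with one six-membered aromatic ring, gives no step beyond the scatter in this assay, and the three steps read (a number 1.7 percentage points lower from compound 3 to compound 4 (within the scatter)), (a number 1 percentage points lower from compound 2 to compound 4 (within the scatter)) and (a number 1.6 percentage points lower from compound 1 to compound 4 (within the scatter)). The earlier compounds shown here showed this flat read-out only among propyl, butyl and pentyl, whereas compound 4 extends it from chains to a substituted aromatic ring at the same position, with no compound among the four going against it. Nothing available offers an explanation for this flat read-out.

The compounds shown leave open whether another group on this aromatic carbon, such as an amine, a carboxylic acid or a much longer chain, would give a number beyond the scatter of these four. They also leave open what would follow from a change elsewhere on the shared core, such as putting hydrogen in place of the bromine or a hydroxyl in place of the methoxy.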